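A few compounds are considered here, and "the series" means these few. Any claim that something is new, unique, unknown or untested is made for them only; others in the source may bear on it.

Of the compounds shown here, two have been measured in a functional assay on U-937 cells (Homo sapiens) for cytotoxicity, read by MTT assay, with a stated time of 48 h; on this read-out lower numbers stand for stronger inhibition and higher numbers for weaker inhibition. Compound 1 `Fc1cccc(-c2nc(Nc3ccccc3)c3cc(F)ccc3n2)c1` gives 45500 nM. Compound 2 `COc1ccc(Nc2nc(-c3cccc(F)c3)nc3ccc(F)cc23)cc1` gives 41100 nM. On these two numbers compound 2 sits at the lower end, but the step of a 1.1-fold lower number from compound 1 to compound 2 (0.04 log units; within the scatter), methoxy in place of hydrogen on an aromatic carbon, lies within the scatter, so no order between the two compounds can be claimed. For the measured compounds named here, that is the only measured step, and it moved the number very little.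

Compound 3 `COc1ccccc1Nc1nc(-c2cccc(F)c2)nc2ccc(F)cc12` has not yet been measured. It differs from compound 2 by 2-methoxyphenyl in place of 4-methoxyphenyl on a nitrogen on an aromatic ring; the two share the same atoms, joined differently. Going by the values given here, no measured step moves the methoxy group from one position on its ring to another. Among the compounds with values here, the only step that bears on the question, a 1.1-fold lower number from compound 1 to compound 2 (0.04 log units; within the scatter), shows that placing this group where it sits in compound 2 changed the number within the scatter, so a step within the scatter is expected here too, with no direction to favour. Compound 3 is therefore expected to give 42000 nM, with a range from 15000 nM to 110000 nM, an expected step of a 1.0-fold higher number from compound 2 to compound 3 (0.01 log units; within the scatter).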

Compound 3, half-maximal inhibitory concentration: > 50000 nM
Compound 3 gave a limit, no number; the forecaster's own chance of this, stated with the estimate: 10%; at least 1.1-fold (0.07 log units) between middle value and limit.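

In this assay compound 3 gives > 50000 nM, which is a limit of the assay and not a number. The change from 4-methoxyphenyl to 2-methoxyphenyl on the nitrogen is an at least 1.2-fold higher number from compound 2 to compound 3 (0.08 log units; that floor lies within the scatter), and the change of hydrogen to methoxy on the aromatic carbon, read this time with the group in its new place, is an at least 1.0-fold higher number from compound 1 to compound 3 (0.04 log units; that floor lies within the scatter); both floors lie within the scatter, so no order among these compounds can be claimed. The new point is that the position of the methoxy group now comes with a step that has a floor but no top, so the data no longer show it to be a small change, and its true size cannot be read because compound 3 reached a limit: the limit of > 50000 nM in this assay, at which 1 of the 3 values shown sits.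

The compounds shown leave open whether a different group on this aromatic ring, such as an amine or a carboxylic acid, would give a number clearly lower than those of compound 1 and compound 2. For the compounds shown here, no step among the three compounds is beyond the scatter, so it also stays open which parts of the shared core matter in this assay.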